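A Methoxy Shift on a Weak Compound

The source may report more compounds than this note shows. Statements on the series, on what has been measured and on what is new or still open speak of the compounds shown alone.

Measured in a functional assay on HeLa cells (Homo sapiens) for inhibition, read by CCK-8 assay, with a stated time of 48 h; a lower number here means a stronger inhibitor, a higher number a weaker inhibitor:
- compound 1 `COc1ccc(NC(=O)NCCNS(=O)(=O)c2ccc(-c3ccccc3OCc3ccccc3)s2)cc1`: > 50000 nM
- compound 2 `O=C(NCCNS(=O)(=O)c1ccc(-c2ccccc2O[C@H]2CC[C@H](O)CC2)s1)Nc1ccc([N+](=O)[O-])cc1`: 10500 nM
- compound 3 `Cc1ccc(-c2ccsc2S(=O)(=O)NCCNC(=O)Nc2cc(C(F)(F)F)cc(C(F)(F)F)c2)c(Oc2ccc(O)c(O)c2)c1`: 9700 nM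

In this assay compound 1 gives > 50000 nM, which is a limit and not a number. That places compound 1 at the limit of > 50000 nM in this assay, at which 1 of the 3 values shown sits. The other two do give numbers, compound 2 at 10500 nM and compound 3 at 9700 nM, but neither is linked to compound 1 by a single change.

Compound 4 `COc1cccc(NC(=O)NCCNS(=O)(=O)c2ccc(-c3ccccc3OCc3ccccc3)s2)c1` has the same atoms as compound 1, joined differently: 3-methoxyphenyl in place of 4-methoxyphenyl on an amide-type nitrogen. It carries 3-methoxyphenyl in place of 4-methoxyphenyl on an amide-type nitrogen, and the rest of the core of compound 1 stays as it is. Among the measured compounds shown here, no measured pair shows what such a change does in this assay, so no shift beyond the scatter is expected, and compound 4 is expected to stay weak. The expected change is a number no higher from compound 1 to compound 4 (the limit leaves the size open). The estimated value for compound 4 is 50000 nM, with an expected range of 20000 nM to 100000 nM.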

Compound 4, half-maximal inhibitory concentration: > 50000 nM
Compound 4: only a limit was reported (the forecaster's own chance of this, stated with the estimate: 60%); the middle value sits exactly at the limit.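

In this assay, compound 4 gives > 50000 nM, a limit and not a number, and compound 1 also stands at a limit, so no step between compound 1 and compound 4 can be read: the limit of > 50000 nM in this assay, at which 2 of the 4 values shown sit.

The compounds shown leave open whether 3-methoxyphenyl in place of 4-methoxyphenyl on an amide-type nitrogen changes the value in this assay at all.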